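Dropping the fluorine from compound 2 in microsomal clearance

The source may hold more compounds than are shown below. What is called first, only, known or untested is meant among the compounds shown, and "the series" means these compounds.

The series shares one core, carried here by compound 2 `O=C(NCc1cc(Cl)ccc1-n1cnnn1)[C@@H]1CC=NN1C(=O)[C@H](O)c1ccccc1F`. Within the data shown here, in an ADME assay on liver for metabolic stability, with Liver microsome (Homo sapiens) as the target, read by LC-MS, using microsomes (a lower number here means slower removal, a higher number faster removal of the compound), compound 2 gives 16 mL.min-1.g-1, the only plain number among the three measured compounds. Compound 1 `CCCC[C@@H](O)C(=O)N1N=CC[C@H]1C(=O)NCc1cc(Cl)ccc1-n1cnnn1` reaches only a limit of this assay, < 12 mL.min-1.g-1. Compound 3 `CC(C)(C)[C@@H](O)C(=O)N1CC(=O)C[C@H]1C(=O)NCc1cc(Cl)ccc1-n1cnnn1` likewise sits at a limit, < 12 mL.min-1.g-1. Among the measured compounds shown here, the one step between measured compounds, an at least 1.3-fold higher number from compound 1 to compound 2 (0.12 log units; that floor lies within the scatter), puts 2-fluorophenyl in place of butyl on a saturated chain carbon bound to a carbonyl carbon and an oxygen on a saturated carbon, and its floor lies within the scatter; two of the three values rest at the limit of < 12 mL.min-1.g-1 in this assay, at which 2 of the 3 values shown sit.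

Compound 4 `O=C(NCc1cc(Cl)ccc1-n1cnnn1)[C@@H]1CC=NN1C(=O)[C@H](O)c1ccccc1` differs from compound 2 by hydrogen in place of fluoro on an aromatic carbon, on an aromatic carbon of a six-membered aromatic ring of carbon only, ortho to a large group. For the measured compounds named here, no measured step touches this change, and the only step known is itself within the scatter, so the step of a 1.1-fold higher number from compound 2 to compound 4 (0.05 log units; within the scatter) is expected to stay within the scatter. Compound 4 is therefore estimated at 18 mL.min-1.g-1 in this assay, between 10 mL.min-1.g-1 and 35 mL.min-1.g-1.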

Compound 4, intrinsic clearance in microsomes: < 12 mL.min-1.g-1
Compound 4 gave a limit, no number; the forecaster's own chance of this, stated with the estimate: 30%; middle value at least 1.5-fold (0.17 log units) from the limit.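

Among these compounds, at this aromatic carbon, hydrogen in place of fluoro gives an at least 1.3-fold lower number from compound 2 to compound 4 (0.12 log units; that floor lies within the scatter) in this assay, the first step to touch this position, and it cannot be told apart from the scatter. Compound 4 rests at a limit of the assay, < 12 mL.min-1.g-1. Compound 2 therefore stays the only compound shown with a plain number, and removing the fluoro puts compound 4 with the others at the limit: the limit of < 12 mL.min-1.g-1 in this assay, at which 3 of the 4 values shown sit.

The step from compound 1 to compound 4, with a limit at each end, cannot be read, so phenyl and butyl remain unranked at that saturated chain carbon. Also open, as far as these compounds go, is whether a chlorine or a methoxy group on this aromatic carbon would give a step beyond the scatter.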